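This account rests on a few compounds, and the source may have more. Where it says the series, first, only, none or still open, it means among the compounds named here.

Compound 1 `Cn1ncc(Cl)c1-c1cc(C(=O)N[C@H]2CNCC[C@@H]2c2ccc(C(F)(F)F)cc2)oc1Cl` gives 127 nM in an assay for inhibition of RAC-alpha serine/threonine-protein kinase (Homo sapiens), read by HTRF, with a stated time of 1 h; a lower number here means a stronger inhibitor, a higher number a weaker inhibitor. Compound 2 `Cn1ncc(Cl)c1-c1cc(C(=O)NC2CNCCC2c2ccc(C(F)(F)F)cc2)oc1Cl` gives 7.2 nM. Compound 3 `Cn1ncc(Cl)c1-c1cc(C(=O)N[C@@H]2CN[C@H](CC(=O)O)C[C@H]2c2ccc(Cl)c(Cl)c2)oc1Cl` gives 1.94 nM.

Compound 3 has the lowest number of the three, with compound 2 nearest and compound 1 furthest away. Among the measured compounds shown here, the only measured step, an 18-fold lower number from compound 1 to compound 2 (1.25 log units; beyond the scatter), concerns the fact that one of compounds 1 and 2 is drawn with a defined configuration and the other without, at the place where they differ and not a change of substituent, so it gives no direct guide here. Compound 4 `CN(C)CC[C@@H]1C[C@@H](c2ccc(Cl)c(Cl)c2)[C@H](NC(=O)c2cc(-c3c(Cl)cnn3C)c(Cl)o2)CN1` differs from compound 3 by (dimethylamino)methyl in place of carboxy on a saturated chain carbon bound to a saturated ring carbon. For the measured compounds named here, no measured pair shows this exchange, so the expectation rests on compound 3 alone, and the step of a 1.5-fold higher number from compound 3 to compound 4 (0.19 log units; within the scatter) is expected to stay within the scatter. Compound 4 is therefore estimated at 3 nM, with a likely range from 0.8 nM to 12 nM.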

Compound 4, half-maximal inhibitory concentration: 3.4 nM
Compound 4: the middle estimate sits 1.1-fold (0.05 log units) below what was measured; low and high end bracket the measured number.
By their numbers in this assay, from the lowest: compounds 3 and 4 (each within the scatter of the next); then compound 2; then compound 1.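

The step of a 1.8-fold higher number from compound 3 to compound 4 (0.24 log units; within the scatter) shows that, on a saturated chain carbon bound to a saturated ring carbon, carboxy and (dimethylamino)methyl cannot be told apart by this measurement. Compounds 1 and 2 carry neither group, so they could not show this. Nothing measured here explains why the exchange leaves the number within the scatter.

As far as these compounds go, it remains open whether an amide, a hydroxyl or a primary amine at this place would also stay within the scatter. A longer chain ending in dimethylamino is equally untested here.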